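A Further Fluoro Group on Compound 2

The source may report more compounds than this note shows. Statements on the series, on what has been measured and on what is new or still open speak of the compounds shown alone.

Compound 1 `O=C(O)c1nnc(O)c2ccccc12` gives 2.42 in a physicochemical assay for lipophilicity (a lower number here means a more polar compound, a higher number a more lipophilic compound), and compound 2 `O=C(O)Cc1nn(Cc2nc3cc(F)ccc3s2)c(=O)c2ccccc12` gives 2.42 in the same measurement, so compound 2 stands level with compound 1 within the scatter. Compound 3 `O=C(O)Cc1nn(Cc2nc3cc(F)cc(F)c3s2)c(=O)c2ccccc12` differs from compound 2 by fluoro in place of hydrogen on an aromatic carbon with fluoro in place of hydrogen on an aromatic carbon, ortho to a fused ring. For the measured compounds named here, no measured step exists for this change. A small upward move of a number 0.18 log units higher from compound 2 to compound 3 (within the scatter) is expected in this assay and would stay within the scatter. The estimate for compound 3 is 2.6 with 2.3 to 2.95 as its expected range.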

Compound 3, partition coefficient: 3.01
Compound 3: the middle estimate sits 0.41 log units below what was measured; the measured number lies above the stated range.
By their numbers in this assay, from the lowest: compounds 1 and 2 (each within the scatter of the next); then compound 3.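

In this assay, fluoro in place of hydrogen on an aromatic carbon, ortho to a fused ring and meta to a fluoro group, gives a number 0.59 log units higher from compound 2 to compound 3 (beyond the scatter). For the compounds shown here, this is the first change in one place measured here, and it shows that a single added fluorine atom at this position can move the number beyond the scatter. Nothing available accounts for the size of this step.

On these data alone, whether a chloro or methyl group on the same carbon would give a similar step remains open. So does whether fluoro there would move the number as far without the other fluoro group.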